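The source may report more compounds than this note shows. Statements on the series, on what has been measured and on what is new or still open speak of the compounds shown alone.

Compound 1 `CC(C)CNc1ccc(NC(=O)c2cc(Cl)ccc2O)c(Cl)c1`: 60000 nM
Compound 2 `O=C(Nc1ccc(NCC2CCCC2)cc1Cl)c1cc(Cl)ccc1O`: 21500 nM
Compound 3 `O=C(Nc1ccc(NCc2ccc(F)cc2)cc1Cl)c1cc(Cl)ccc1O`: 54400 nM

These values come from an ADME assay on A549 cells (Homo sapiens) for cytotoxicity, read by resazurin assay, with a stated time of 48 h; on this read-out higher numbers stand for lower toxicity in this test and lower numbers for higher toxicity in this test. Compound 3 stands with compound 1 at the high end: there is a 1.1-fold lower number from compound 1 to compound 3 (0.04 log units; within the scatter), while the other comparison shows a 2.5-fold higher number from compound 2 to compound 3 (0.40 log units; beyond the scatter). Compound 4 `COc1ccc(CNc2ccc(NC(=O)c3cc(Cl)ccc3O)c(Cl)c2)cc1` has methoxy in place of fluoro on an aromatic carbon, para to a large group (methoxy in place of fluoro on an aromatic carbon). Among the compounds with values here, no measured step makes this swap. The closest evidence comes from replacing the whole group on the saturated chain carbon, where a 2.8-fold lower number from compound 1 to compound 2 (0.45 log units; beyond the scatter) was the largest step and was only modest. A step no larger than the scatter is therefore expected, and the expected step is a 1.2-fold lower number from compound 3 to compound 4 (0.08 log units; within the scatter). The estimate for compound 4 is 45000 nM, with an expected range of 20000 nM to 90000 nM.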

Compound 4, half-maximal cytotoxic concentration: 80700 nM
For compound 4 the middle estimate is 1.8-fold (0.25 log units) below the measured one; the range from low to high includes it.
By their numbers in this assay, from the lowest: compound 2; then compounds 3, 1 and 4 (each within the scatter of the next).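

In this assay, the change from 4-fluorobenzyl to 4-methoxybenzyl leaves the number within the scatter (a 1.5-fold higher number from compound 3 to compound 4 (0.17 log units; within the scatter)), so this aromatic place accepts either fluoro or methoxy without a clear shift. The 4-methoxyphenyl group also stays level with isopropyl (a 1.3-fold higher number from compound 1 to compound 4 (0.13 log units; within the scatter)), while cyclopentyl remains the group that stands apart, with higher toxicity in this test (a 3.8-fold higher number from compound 2 to compound 4 (0.57 log units; beyond the scatter)). Nothing measured here explains these steps.

The compounds shown leave open whether an amine or a carboxylic acid at this aromatic place would shift the number. They also leave open how a longer chain on the nitrogen would compare with cyclopentyl.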